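The compounds below may be only part of what the source reports. "The series", "measured", "known", "first", "only" and "open" are said of these compounds alone.

Compound 2 `CC(=O)N1CCN(CCCCOc2ccccc2/C=C/c2ccccc2)CC1` gives 0% in a functional assay on the whole organism with Mus musculus as the target, in the maximal electroshock model, at a dose of 50 mg/kg by the oral route (a lower number here means less inhibition, a higher number more inhibition at the dose given (going by the name of the read-out)), level with compound 1 `CCCN(CCC)CCCCOc1ccccc1/C=C/c1ccccc1`, which gives 0%. For the measured compounds named here, the single measured step, no change at the digits printed from compound 1 to compound 2 (within the scatter), shows no change within the scatter. Compound 3 `OCC1CCCN(CCCCOc2ccccc2/C=C/c2ccccc2)C1` differs from compound 2 by 3-(hydroxymethyl)piperidin-1-yl in place of 4-acetylpiperazin-1-yl on a saturated chain carbon, four bonds along the chain from an oxygen on an aromatic ring. Going by the values given here, the one measured step at this position bears on it only loosely, since the entering group is of another kind, and no further comparison exists; the expected step is therefore a number 5 percentage points higher from compound 2 to compound 3 (within the scatter). Compound 3 is estimated at 5% in this assay, within a range from 0% to 30%.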

Compound 3, a percentage reported as inhibition, in the whole organism at one dose (the size of the read-out at that dose, not a potency): 12.5%
The estimate for compound 3 lay 7.5 percentage points below the measured number; measured number inside the range.
By their numbers in this assay, from the lowest: compounds 1 and 2 (each within the scatter of the next); then compound 3.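

Putting 3-(hydroxymethyl)piperidin-1-yl on the saturated chain carbon, four bonds along the chain from an oxygen on an aromatic ring, gives a number 12.5 percentage points higher from compound 2 to compound 3 (beyond the scatter) and a number 12.5 percentage points higher from compound 1 to compound 3 (beyond the scatter) in this assay. For the compounds shown here, this is the first change at this position with a step beyond the scatter, so the group at this place can alter the read-out, though only modestly. Nothing measured here explains the step. Going by these compounds, it remains open whether plain piperidin-1-yl or morpholin-4-yl would give a similar number. On these data alone, how a longer chain would affect the read-out also remains open.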